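The source may report more compounds than this note shows. Statements on the series, on what has been measured and on what is new or still open speak of the compounds shown alone.

Compound 1 `Nc1nc2ccccn2c1-c1ccc(O)cc1`: in an assay on isolated protein for inhibition of ubiquitin carboxyl-terminal hydrolase 1 (Homo sapiens) (a higher number here means a weaker inhibitor, a lower number a stronger inhibitor), compound 1 gives only a limit, > 100000 nM.
Compound 2 `CN(C)c1nc2ccccn2c1-c1ccc(O)cc1`: in this assay compound 2 gives only a limit, > 100000 nM.
Compound 3 `COc1ccc(-c2c(N)nc3ccccn23)cc1`: in this assay compound 3 gives only a limit, > 100000 nM.

Compound 1 therefore has no measured number of its own; it stands at the limit of > 100000 nM in this assay, at which 3 of the 3 values shown sit. The two changes made from it, the dimethylamino in place of amino on an aromatic carbon and the methyl in place of hydrogen on an oxygen on an aromatic ring, each gave a step that the two limits leave unreadable from compound 1 to compound 2 and a step that the two limits leave unreadable from compound 1 to compound 3, so neither tells how large a change at any position on this core can be.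

Compound 4 `Nc1nc2cc(C(F)(F)F)ccn2c1-c1ccc(O)cc1` differs from compound 1 by trifluoromethyl in place of hydrogen on an aromatic carbon. For the measured compounds named here, no measured step touches this position, and the two measured steps are unreadable, so nothing sets a size or direction beyond an expectation of no readable change. The step from compound 1 to compound 4 is expected to be a number no higher from compound 1 to compound 4 (the limit leaves the size open). Compound 4 is therefore expected to remain at the same limit, with an estimate of 100000 nM, ranging from 30000 nM to 300000 nM.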

Compound 4, half-maximal inhibitory concentration: > 100000 nM
Compound 4: a limit, no number; the forecaster's own chance of this, stated with the estimate: 85%; the middle value lies on the limit itself.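

Compound 4, like compound 1, gives only a limit and no number, so the step between them cannot be read. The compounds shown leave open how strongly anything on this shared core inhibits, and whether any change moves that value, as all share one limit: the limit of > 100000 nM in this assay, at which 4 of the 4 values shown sit.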